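From Benzamido to Phenethyloxy on the Shared Core

The compounds below may be only part of what the source reports. "The series", "measured", "known", "first", "only" and "open" are said of these compounds alone.

Three analogues of one core were measured in a functional assay on HEK293 cells for agonist activity at G-protein coupled receptor 39 (Homo sapiens), read by scintillation proximity assay and inositol phosphate accumulation, with a stated time of 75 min; on this read-out lower numbers stand for an effect already at smaller amounts and higher numbers for an effect only at larger amounts of compound. Compound 1 `Cc1nn(-c2ncnc3nc[nH]c23)c2c1C(OCc1ccccc1F)CC(=O)N2` gives 78 nM, compound 2 `Cc1nn(-c2ncnc3nc[nH]c23)c2c1C(C(=O)N(C)c1nccs1)CC(=O)N2` gives 3300 nM, and compound 3 `Cc1nn(-c2ncnc3nc[nH]c23)c2c1C(NC(=O)c1ccccc1)CC(=O)N2` gives 158 nM, the second highest number of the three. The measured steps show a 2.0-fold higher number from compound 1 to compound 3 (0.31 log units; beyond the scatter), a 42-fold higher number from compound 1 to compound 2 (1.63 log units; beyond the scatter) and a 21-fold lower number from compound 2 to compound 3 (1.32 log units; beyond the scatter). Compound 4 `Cc1nn(-c2ncnc3nc[nH]c23)c2c1C(OCCc1ccccc1)CC(=O)N2` carries phenethyloxy in place of benzamido on a saturated ring carbon. The (2-fluorobenzyl)oxy analogue bears most on this change, because in this assay compound 1 gave 78 nM, while the methyl(1,3-thiazol-2-yl)carbamoyl analogue, compound 2, stands far away. A modest lowering of the number is therefore expected, a 1.6-fold lower number from compound 3 to compound 4 (0.20 log units; within the scatter), though a result within the scatter would not surprise. Compound 4 is estimated at 100 nM, with a range from 30 nM to 400 nM.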

Compound 4, half-maximal effective concentration: 40 nM
The estimate for compound 4 lay 2.5-fold (0.40 log units) above the measured number; the range from low to high includes it.
By their numbers in this assay, from the lowest: compounds 4 and 1 (each within the scatter of the next); then compound 3; then compound 2.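

In this assay, phenethyloxy on the saturated ring carbon improves on benzamido (a 4.0-fold lower number from compound 3 to compound 4 (0.60 log units; beyond the scatter)) and far outdoes the methyl(1,3-thiazol-2-yl)carbamoyl group (an 83-fold lower number from compound 2 to compound 4 (1.92 log units; beyond the scatter)), while carrying no hydrogen-bond donor. Against the (2-fluorobenzyl)oxy group, it shows no separation beyond the usual scatter (a 2.0-fold lower number from compound 1 to compound 4 (0.29 log units; within the scatter)), so benzyl in place of 2-fluorophenyl leaves the number effectively level. Nothing available explains these steps.

The compounds shown leave open whether a fluorine on the phenethyloxy ring would change the number. Also open, from the compounds shown here alone, is how a longer chain, or an amine in place of the ether oxygen, would fare at this position.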